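A few compounds are considered here, and "the series" means these few. Any claim that something is new, unique, unknown or untested is made for them only; others in the source may bear on it.

Measured in a functional assay on DU-145 cells (Homo sapiens) for inhibition, read by trypan blue exclusion, with a stated time of 96 h; on this read-out lower numbers stand for stronger inhibition of growth and higher numbers for weaker inhibition of growth:
compound 1 `O=C(/C(=C\c1cc(Br)c(O)c(Br)c1)SCc1ccc(Br)cc1)c1ccc(Br)cc1`: 1000 nM
compound 2 `CCOc1ccc(/C=C(/SCc2ccc(C)cc2)C(=O)c2ccc(Cl)cc2)cc1OC`: 25000 nM

Compound 1 has the lowest number of the two; the number for compound 2 is higher by a gap beyond the scatter. Compound 3 `O=C(/C(=C\c1cc(Cl)c(O)c(Cl)c1)SCc1ccc(Br)cc1)c1ccc(Br)cc1` is not yet measured. It differs from compound 1 by 3,5-dichloro-4-hydroxyphenyl in place of 3,5-dibromo-4-hydroxyphenyl on a double-bonded chain carbon bound to a double-bonded chain carbon. Going by the values given here, no step between measured compounds is available for this change. The step from compound 1 to compound 3 is expected to be small, a 1.5-fold higher number from compound 1 to compound 3 (0.18 log units; within the scatter), not beyond the scatter in either direction. Compound 3 is estimated at 1500 nM, with a range of 500 nM to 5000 nM.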

Compound 3, concentration for 50% growth inhibition: 10000 nM
Estimate against measurement, compound 3: 6.7-fold (0.82 log units) below; the whole stated range lies below it.
By their numbers in this assay, from the lowest: compound 1; then compound 3; then compound 2.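

At this position, on a double-bonded chain carbon bound to a double-bonded chain carbon, the two halogen forms of the phenol group are not interchangeable: in this assay, 3,5-dichloro-4-hydroxyphenyl in place of 3,5-dibromo-4-hydroxyphenyl brings a 10-fold higher number from compound 1 to compound 3 (1.00 log units; beyond the scatter) on the shared core. The two groups have equal counts of heavy atoms, donors and acceptors, so these counts do not separate them. Nothing measured here accounts for the step.

Still open, on these data alone, is how 3,5-diiodo-4-hydroxyphenyl or 3,5-dimethyl-4-hydroxyphenyl would read at this position. Also open, as far as these compounds go, is whether an amine could stand in place of the hydroxyl.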